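Methyl on Sulfur: From Compound 3 to Compound 4

The source may hold more compounds than are shown below. What is called first, only, known or untested is meant among the compounds shown, and "the series" means these compounds.

Three compounds have been measured so far:
compound 1, `CSc1nc(NCCCCCO)c2ccccc2n1`, 71400 nM
compound 2, `COc1ccc(CNc2nc(SC)nc3ccccc23)cc1`, > 100000 nM
compound 3, `Sc1nc(NCc2ccccc2)c2ccccc2n1`, > 100000 nM

All three share one core and were tested in a functional assay on HTB-54 cells (Homo sapiens) for cytotoxicity, read by MTT assay, with a stated time of 72 h; a higher number here means a weaker inhibitor of growth, a lower number a stronger inhibitor of growth. Compound 1 gives 71400 nM in this assay. For compound 2 the value > 100000 nM is a limit of the assay, not a number. For compound 3 the value > 100000 nM is likewise a limit of the assay rather than a number. Compound 3 thus stands at the limit of > 100000 nM in this assay, at which 2 of the 3 values shown sit, and nothing more can be said of its exact place.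

Compound 4, `CSc1nc(NCc2ccccc2)c2ccccc2n1`, is not yet measured. It differs from compound 3 by methyl in place of hydrogen on a sulfur. Compound 1 and compound 2 already carry the methylsulfanyl group, and compound 2 sits at the same limit as compound 3. The step from compound 3 to compound 4 is therefore expected to be small or none beyond the scatter, an at least 1.1-fold lower number from compound 3 to compound 4 (0.04 log units; that floor lies within the scatter). Compound 4 is expected to give about 90000 nM in this assay, most likely between 40000 nM and 200000 nM.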

Compound 4, concentration for total growth inhibition: 82300 nM
For compound 4 the middle estimate is 1.1-fold (0.04 log units) above the measured one, and the stated range covers the measured number.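

In this assay methyl in place of hydrogen on the sulfur gives an at least 1.2-fold lower number from compound 3 to compound 4 (0.08 log units; that floor lies within the scatter) and hydrogen in place of methoxy on an aromatic carbon gives an at least 1.2-fold lower number from compound 2 to compound 4 (0.08 log units; that floor lies within the scatter), and neither floor shows a real change. Phenyl in place of 4-hydroxybutyl on a saturated chain carbon bound to a nitrogen on an aromatic ring gives a 1.2-fold higher number from compound 1 to compound 4 (0.06 log units; within the scatter) and so, with methylsulfanyl present in both compounds, these two groups cannot be told apart in this assay. Both floors start from a limit, which leaves their true size unknown: the limit of > 100000 nM in this assay, at which 2 of the 4 values shown sit.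

From the compounds shown here alone, whether a longer chain on the sulfur, or an amine or a carboxylic acid carried on such a chain, would move the number beyond the scatter stays open. Going by these compounds, the true place of compound 3 also stays open.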